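Methyl on the thiophene: half-life of compound 4

A few compounds are considered here, and "the series" means these few. Any claim that something is new, unique, unknown or untested is made for them only; others in the source may bear on it.

Measured compounds:
compound 1 `NC(=O)COc1ccc2c(c1)S(=O)(=O)N=C(c1c(O)c(-c3cccs3)nn(CCC3CC3)c1=O)N2` gives 0.2 h in an in vitro ADME assay on microsomes from liver (Homo sapiens) for metabolic stability; on this read-out higher numbers stand for a longer-lived compound and lower numbers for a shorter-lived compound
compound 2 `NC(=O)COc1ccc2c(c1)S(=O)(=O)N=C(c1c(O)c(-c3cccs3)nn(CC3CCCCC3)c1=O)N2` gives > 1 h in this assay, which is a limit of the assay and not a number
compound 3 `NC(=O)COc1ccc2c(c1)S(=O)(=O)N=C(c1c(O)c(-c3ccsc3)nn(CCC3CC3)c1=O)N2` gives 0.267 h in this assay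

Compound 3 and compound 1 lie within the usual scatter of each other, as the step of a 1.3-fold higher number from compound 1 to compound 3 (0.13 log units; within the scatter) shows; the third value shown is a limit, as in the limit of > 1 h in this assay, at which 1 of the 3 values shown sits. The unmeasured compound 4 `Cc1ccc(-c2nn(CCC3CC3)c(=O)c(C3=NS(=O)(=O)c4cc(OCC(N)=O)ccc4N3)c2O)s1` differs from compound 3 in one place: 5-methylthiophen-2-yl in place of thiophen-3-yl on an aromatic carbon.

Within the data shown here, two measured steps touch the shared core. The step of an at least 5.0-fold higher number from compound 1 to compound 2 (0.69 log units; beyond the scatter) changed the group on the ring nitrogen, not the thiophene, and so does not bear on this change. Among the measured compounds shown here, the step of a 1.3-fold higher number from compound 1 to compound 3 (0.13 log units; within the scatter) swapped one thiophene attachment point for the other and stayed within the scatter; it is the only step at the same position, and it did not move the number. Adding a methyl group to the thiophene has no measured precedent here. The expected step is therefore small: a 1.1-fold higher number from compound 3 to compound 4 (0.05 log units; within the scatter), with no direction beyond the scatter. Compound 4 is estimated at 0.3 h in this assay, within a range from 0.12 h to 0.8 h.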

Compound 4, half-life: 0.7 h
For compound 4 the middle estimate is 2.3-fold (0.37 log units) below the measured one; measured number inside the range.
By their numbers in this assay, from the lowest: compounds 1 and 3 (each within the scatter of the next); then compound 4. At a limit, above all of these: compound 2.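

In this assay, the thiophene position had looked silent: moving the attachment point left compound 1 and compound 3 within the scatter of each other. Adding one methyl group changes that picture, with a 3.5-fold higher number from compound 1 to compound 4 (0.54 log units; beyond the scatter), and this is the cleanest reading of the change, as methyl in place of hydrogen is the only difference between those two compounds. The comparison with the other thiophene isomer points the same way, with a 2.6-fold higher number from compound 3 to compound 4 (0.42 log units; beyond the scatter), so the group on the ring nitrogen, as in an at least 5.0-fold higher number from compound 1 to compound 2 (0.69 log units; beyond the scatter), is no longer the only place shown to move the half-life beyond the scatter.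

As far as these compounds go, whether an ethyl group, a chlorine atom or an amine at the same thiophene carbon would go the same way stays open, as does the effect of a methyl group on thiophen-3-yl. How 5-methylthiophen-2-yl would combine with the ring-nitrogen group of compound 2 also stays open, and the value of compound 2 is a limit and not a number: the limit of > 1 h in this assay, at which 1 of the 4 values shown sits.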